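Urea-to-amide step in the pyrazole series

The compounds below may be only part of what the source reports. "The series", "measured", "known", "first", "only" and "open" are said of these compounds alone.

Compound 2 `COc1cc(Cl)cc(-c2nn(-c3cccc(NC(=O)Nc4ccc(Cl)c(C(F)(F)F)c4)c3)cc2-c2ccncc2)c1` gives 31% in a functional assay on SF-295 cells (Homo sapiens) for inhibition, read by sulforhodamine B assay, with a stated time of 48 h, tested at 1 uM (on this read-out higher numbers stand for a weaker effect at the one concentration tested and lower numbers for a stronger effect), and on the numbers shown it stands second highest of three. Compound 1 `O=C(Nc1cccc(-n2cc(-c3ccncc3)c(-c3cc(O)cc(Cl)c3)n2)c1)Nc1ccc(Cl)c(C(F)(F)F)c1` gives 91%, and compound 3 `COc1cc(Cl)cc(-c2nn(-c3cccc(NC(=O)Nc4cc(C(F)(F)F)cc(C(F)(F)F)c4)c3)cc2-c2ccncc2)c1` gives 12%. Among the measured compounds shown here, the only single-place step measured is a number 60 percentage points lower from compound 1 to compound 2 (beyond the scatter), a methyl in place of hydrogen on an oxygen on an aromatic ring. Compound 3 differs from compound 2 in more than one place, so its number is only noted alongside that of compound 2 without a step.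

Compound 4 `COc1cc(Cl)cc(-c2nn(-c3cccc(NC(=O)c4cccc(C(F)(F)F)c4)c3)cc2-c2ccncc2)c1` carries the change (3-(trifluoromethyl)phenyl in place of (4-chloro-3-(trifluoromethyl)phenyl)amino on a carbonyl carbon). For the measured compounds named here, no measured step touches the urea end of the molecule, so the expectation rests on the spread of the three numbers rather than on a matching precedent. The loss of the amino link and of the chlorine on that ring is a larger alteration than the methyl step between compound 1 and compound 2, and the effect at this concentration is expected to weaken. For compound 4 the estimated read-out in this assay is 55%, with a range from 25% to 85%. The expected step is a number 24 percentage points higher from compound 2 to compound 4 (beyond the scatter), and a number within scatter of compound 2 is not excluded.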

Compound 4, a percentage reported as activity, at one concentration (the size of the read-out at that concentration, not a potency): 57%
Compound 4: middle estimate off by 2 percentage points, on the low side; measured number inside the range.
By their numbers in this assay, from the lowest: compound 3; then compound 2; then compound 4; then compound 1.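

In this assay the swap of (4-chloro-3-(trifluoromethyl)phenyl)amino for 3-(trifluoromethyl)phenyl on a carbonyl carbon gives a number 26 percentage points higher from compound 2 to compound 4 (beyond the scatter) and so shows that this end of the molecule also moves the read-out, which the earlier single-place step, made on an oxygen on an aromatic ring, could not show. The weaker effect at the one concentration tested belongs to the swap as a whole, since the amino nitrogen with its hydrogen-bond donor and the chlorine leave together, and the data do not divide the step between them. Nothing available on the series accounts for the size of this step.

Open, going by these compounds, is which part carries the step: (3-(trifluoromethyl)phenyl)amino on the same carbonyl carbon would keep the amino link without the chlorine, and 4-chloro-3-(trifluoromethyl)phenyl there would keep the chlorine without the amino link. Also open, on these data alone, is whether the same swap gives a step of similar size with the hydroxy group of compound 1 in place of the methoxy group of compound 2, and whether a read-out at a single concentration tracks potency.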